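Methyl on the amide nitrogen of compound 1

This account rests on a few compounds, and the source may have more. Where it says the series, first, only, none or still open, it means among the compounds named here.

Compound 1 `CCNC(=O)c1sc(-c2ccccc2)nc1O` stands at the edge of what an assay on HEK293 cells for inhibition of transient receptor potential cation channel subfamily M member 8 (Homo sapiens), read by FLIPR, with stated times of 5 min and 3 min (a higher number here means a weaker inhibitor, a lower number a stronger inhibitor), can report: compound 1 gives > 100000 nM, which is a limit of the assay and not a number, as the limit of > 100000 nM in this assay, at which 1 of the 3 values shown sits, shows. Compound 2 `CCOC(=O)c1sc(-c2ccc(C)cc2)nc1O` gives 160 nM in this assay. Compound 3 `CCn1nnc(-c2sc(-c3ccccc3O)nc2O)n1` gives 24 nM in this assay. Compound 4 `CCN(C)C(=O)c1sc(-c2ccccc2)nc1O` differs from compound 1 by methyl in place of hydrogen on an amide-type nitrogen. No step between measured compounds covers this change, and compound 1 offers no number to start from, so the direction of the step cannot be read from the data shown. Compound 4 is expected to stay weak, with an expected step of an at least 1.2-fold lower number from compound 1 to compound 4 (0.09 log units; that floor lies within the scatter). Compound 4 is estimated at 80000 nM in this assay, likely between 10000 nM and 300000 nM.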

Compound 4, half-maximal inhibitory concentration: 6400 nM
For compound 4 the middle estimate is 13-fold (1.10 log units) above the measured one; measured number outside the range, below it.
By their numbers in this assay, from the lowest: compound 3; then compound 2; then compound 4. At a limit, above all of these: compound 1.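

Methyl in place of hydrogen on this amide-type nitrogen gives, in this assay, an at least 15-fold lower number from compound 1 to compound 4 (1.19 log units; beyond the scatter), so the first number at this position shows that the nitrogen tolerates a second substituent and that the series responds to the change. Compound 1 gives > 100000 nM, which is a limit of the assay and not a number. The step is therefore only a floor, and its true size stays unknown, because one end of it is a limit: the limit of > 100000 nM in this assay, at which 1 of the 4 values shown sits.

Open, from the compounds shown here alone, is whether a propyl group or a longer chain on this nitrogen, or a pyrrolidine ring closed over it, moves the number further in the same direction.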